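This account rests on a few compounds, and the source may have more. Where it says the series, first, only, none or still open, it means among the compounds named here.

Measured so far in an ADME assay on microsomes from liver (Homo sapiens) for metabolic stability, read by LC-MS, with NADPH named in the record, with a stated time of 60 min, tested at 1 uM, in the absence of a further agent; a higher number here means that more of the compound is left, a lower number that less of the compound is left:
- Compound 1 `COc1ccc(-c2c(C)nc3c(N4CC[C@@H](NC(=O)COc5ccccc5)C4)cc(C)nn23)cc1OC`: > 95%, a limit
- Compound 2 `COc1ccc(-c2c(C)nc3c(N4CC[C@@H](NC(=O)Nc5ccccc5)C4)cc(C)nn23)cc1OC`: > 95%, a limit
- Compound 3 `COc1ccc(-c2c(C)nc3c(N4CC[C@@H](NS(N)(=O)=O)C4)cc(C)nn23)cc1OC`: > 95%, a limit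

Compound 3 stands only at a limit, > 95%, and not at a number. It shares this position with the other two measured compounds: the limit of > 95% in this assay, at which 3 of the 3 values shown sit.

Compound 4 `COc1ccc(-c2c(C)nc3c(N4CCCC4)cc(C)nn23)cc1OC` has hydrogen in place of sulfamoylamino on a saturated ring carbon, so 3-(sulfamoylamino)pyrrolidin-1-yl becomes pyrrolidin-1-yl: hydrogen in place of sulfamoylamino on a saturated ring carbon.

Among the compounds with values here, three measured steps bear on this change: a step that the two limits leave unreadable from compound 1 to compound 2, a step that the two limits leave unreadable from compound 1 to compound 3 and a step that the two limits leave unreadable from compound 2 to compound 3. All three exchange the group on the amine nitrogen, none removes it, and none has a readable size. They therefore give only weak guidance for a change that removes the group entirely.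

In this assay, the expected step is a number at least 3 percentage points lower from compound 3 to compound 4 (that floor lies within the scatter), small and towards less compound left, and it may stay within the scatter. For compound 4 the estimate is 92%, with an expected range from 72% to 100%.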

Compound 4, percent of the compound remaining: > 95%
Compound 4 gave a limit, no number; the forecaster's own chance of this, stated with the estimate: 45%; at least 3 percentage points between middle value and limit.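

In this assay compound 4 gives > 95%, a limit and not a number. No step from compound 1, compound 2 or compound 3 to compound 4 can be read: the limit of > 95% in this assay, at which 4 of the 4 values shown sit.

The compounds shown leave open whether hydrogen in place of sulfamoylamino changes the percent of compound remaining at all.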